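A few compounds are considered here, and "the series" means these few. Any claim that something is new, unique, unknown or untested is made for them only; others in the source may bear on it.

Measured values in an ADME assay on HepG2 cells (Homo sapiens) for cytotoxicity, read by CellTiter-Glo and resazurin assay, with a stated time of 72 h; on this read-out higher numbers stand for an effect only at larger amounts of compound and lower numbers for an effect already at smaller amounts:
Compound 1 `CC(C)N(Cc1cccc(OCCCCCC(=O)O)c1)C(=O)c1ccc(-c2cccc3ccccc23)cc1` gives > 26000 nM, which is a limit of the assay rather than a number.
Compound 2 `CC(C)N(Cc1cccc(OCCCCCC(=O)O)c1)C(=O)c1ccc(-c2ccncc2)cc1` gives > 26000 nM, again only a limit.
Compound 3 `CC(C)N(Cc1cccc(OCCCCCC(=O)O)c1)C(=O)c1ccc(-c2cccc(-c3ccccc3)c2)cc1` gives > 26000 nM, once more a limit.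

Compound 3 thus stands where every value in this set stands: at the limit of > 26000 nM in this assay, at which 3 of the 3 values shown sit. Among the compounds with values here, no compound here has produced a readable number, and the three comparisons between them are correspondingly unreadable. The change a step that the two limits leave unreadable from compound 1 to compound 3 and the change a step that the two limits leave unreadable from compound 2 to compound 3 are the two steps that end at compound 3, and neither shows a size; the same is true of a step that the two limits leave unreadable from compound 1 to compound 2.

Compound 4 `CC(C)N(Cc1cccc(OCCCCCC(=O)O)c1)C(=O)c1ccc(-c2cccc(Oc3ccccc3)c2)cc1` differs from compound 3 by phenoxy in place of phenyl on an aromatic carbon. Within the data shown here, no measured step involves a phenoxy group, so the only guidance comes from the steps just named, all of which are hidden by the limit. The step from compound 3 to compound 4 is therefore expected to be a step that the limit leaves unreadable from compound 3 to compound 4, that is, nothing readable beyond the scatter, with compound 4 most probably also reported as a limit. Compound 4 is estimated at 40000 nM, with a range from 20000 nM to 120000 nM.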

Compound 4, half-maximal effective concentration: > 18700 nM
Compound 4: a limit, no number; the forecaster's own chance of this, stated with the estimate: 85%; the middle value is on the limit's open side.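

In this assay compound 4 gives > 18700 nM, which is a limit and not a number. Compound 3 gives > 26000 nM, also only a limit, so the swap of phenyl for phenoxy between compound 3 and compound 4 cannot be read as a step. The compounds shown leave open whether this change alters the half-maximal effective concentration at all.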